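Swapping the Difluorophenyl for a Chlorophenyl

The compounds below may be only part of what the source reports. "The series", "measured", "known", "first", "only" and "open" are said of these compounds alone.

Compound 3 `Cc1cc(C(=O)O)nn1Cc1cc(Br)ccc1OCc1c(F)cccc1F` gives the highest number of the three measured compounds in an assay on CHO-K1 cells for displacement of a labelled ligand from prostaglandin E2 receptor EP1 subtype (Homo sapiens) (a higher number here means a weaker inhibitor, a lower number a stronger inhibitor), at 14.8 nM. Compound 1 `Cc1cc(C(=O)O)nn1Cc1cc(Br)ccc1OCc1ccc(Cl)cc1Cl` gives 0.132 nM and compound 2 `Cc1cc(C(=O)O)nn1Cc1cc(Br)ccc1OCc1ccc(F)cc1F` gives 0.525 nM, so compound 3 is the weakest of the three. The measured steps were a 110-fold higher number from compound 1 to compound 3 (2.05 log units; beyond the scatter), a 28-fold higher number from compound 2 to compound 3 (1.45 log units; beyond the scatter) and a 4.0-fold higher number from compound 1 to compound 2 (0.60 log units; beyond the scatter).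

Compound 4 `Cc1cc(C(=O)O)nn1Cc1cc(Br)ccc1OCc1cccc(Cl)c1` differs from compound 3 by 3-chlorophenyl in place of 2,6-difluorophenyl on a saturated chain carbon bound to an oxygen on an aromatic ring. Among the compounds with values here, no measured step tests a single chlorine in this position, but both steps leading to the 2,6-difluorophenyl of compound 3 gave a much higher number, and the chlorine-bearing compound 1 gave the lowest number of all. A clear drop in this assay is therefore expected. Compound 4 carries only one halogen, so the step is expected to stop short of the full return to the number of compound 1, 0.132 nM. Compound 4 is expected at 1.5 nM, in the range 0.3 nM to 8 nM, a step of a 9.9-fold lower number from compound 3 to compound 4 (0.99 log units; beyond the scatter).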

Compound 4, half-maximal inhibitory concentration: 115 nM
Estimate against measurement, compound 4: 77-fold (1.88 log units) below; the measured number lies above the stated range.
By their numbers in this assay, from the lowest: compound 1; then compound 2; then compound 3; then compound 4.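

With the 3-chlorophenyl group, compound 4 is the weakest of the four in this assay, showing a 7.8-fold higher number from compound 3 to compound 4 (0.89 log units; beyond the scatter), a 220-fold higher number from compound 2 to compound 4 (2.34 log units; beyond the scatter) and an 870-fold higher number from compound 1 to compound 4 (2.94 log units; beyond the scatter). A chlorine on this ring therefore does not by itself give a low number, since the 2,4-dichlorophenyl of compound 1 and the 3-chlorophenyl of compound 4 lie at opposite ends of the series, and even the two difluorophenyl groups of compound 2 and compound 3 do better than the 3-chlorophenyl. No measurement available here explains this rise.

The step from the 2,4-dichlorophenyl to the 3-chlorophenyl changes both the number and the placement of the chlorines, so the two effects cannot be told apart. On these data alone, how a plain phenyl group or a methoxyphenyl group would compare on the same saturated chain carbon remains open.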